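Propyl to isopropyl: one chain end rearranged

A few compounds are considered here, and "the series" means these few. Any claim that something is new, unique, unknown or untested is made for them only; others in the source may bear on it.

compound 1 `COc1cccc(Nc2nc3c(c(Oc4cccc(NC(=O)/C=C/C(C)C)c4)n2)CSCC3)c1` gives > 50000 nM
compound 2 `C/C=C/C(=O)Nc1cccc(Oc2nc(Nc3cccc(C#N)c3)nc3c2CSCC3)c1` gives > 50000 nM
compound 3 `CCC/C=C/C(=O)Nc1cccc(Oc2nc(Nc3cccc(C#N)c3)nc3c2CSCC3)c1` gives > 50000 nM

In an ADME assay on L02 cells (Homo sapiens) for cytotoxicity, read by MTT assay, with a stated time of 72 h (on this read-out lower numbers stand for stronger inhibition and higher numbers for weaker inhibition), compound 3 reports only a limit (> 50000 nM), not a number. All three compounds share that position (the limit of > 50000 nM in this assay, at which 3 of the 3 values shown sit). Compound 4 `CC(C)/C=C/C(=O)Nc1cccc(Oc2nc(Nc3cccc(C#N)c3)nc3c2CSCC3)c1` has the same atoms as compound 3, joined differently (isopropyl in place of propyl on a double-bonded chain carbon bound to a double-bonded chain carbon). Among the compounds with values here, the one measured step that bears on this (a step that the two limits leave unreadable from compound 2 to compound 3) has no readable size, so it offers no guide. Compound 1 carries the same (3-methylbut-1-en-1-yl)carbonyl group, with another change elsewhere, and it too is only a limit (> 50000 nM). The expected step (a number no higher from compound 3 to compound 4 (the limit leaves the size open)) is none beyond the scatter, with no direction foreseen. The estimate for compound 4 is 50000 nM (expected range 25000 nM to 100000 nM).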

Compound 4, half-maximal inhibitory concentration: > 50000 nM
Compound 4 ended at the assay's limit; the forecaster's own chance of this, stated with the estimate: 85%; the middle value sits exactly at the limit.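

Within the data shown here, compound 1, compound 2, compound 3 and compound 4 all end at a limit rather than a number, so no step among them can be read: the limit of > 50000 nM in this assay, at which 4 of the 4 values shown sit. Left open is how far each compound lies past that limit in this assay, and whether isopropyl in place of propyl changes anything there.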